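The source may hold more compounds than are shown below. What is called first, only, known or untested is meant among the compounds shown, and "the series" means these compounds.

Series notes. Compound 1 `CN1C/C(=C\c2cccnc2)C(=O)/C(=C/c2ccccc2F)C1` carries a methyl on the amine nitrogen in the ring; in a functional assay on HepG2 cells (Homo sapiens) for cytotoxicity, read by MTT assay, with a stated time of 24 h (a lower number here means a stronger inhibitor, a higher number a weaker inhibitor), compound 1 gives 4810 nM. Compound 2 `N#Cc1ccc(S(=O)(=O)N2C/C(=C\c3cccnc3)C(=O)/C(=C/c3ccccc3F)C2)cc1` carries (4-cyanophenyl)sulfonyl in place of that methyl, and in this assay compound 2 gives 6600 nM. Within the data shown here, that single change gave a 1.4-fold higher number from compound 1 to compound 2 (0.14 log units; within the scatter), so the two measured compounds are not separated by more than the scatter; compound 2 holds the higher of the two numbers, with compound 1 as the only neighbour.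

Compound 3 `N#Cc1ccc(S(=O)(=O)N2C/C(=C\c3cccnc3)C(=O)/C(=C/c3ccccc3C(F)(F)F)C2)cc1` is the next member, differing from compound 2 only at the aromatic ring: trifluoromethyl in place of fluoro on an aromatic carbon. Among the measured compounds shown here, no measured step touches this ring; the sole step on record, from compound 1 to compound 2, concerns the amine nitrogen and stays within the scatter, so it carries no information on the direction of a fluoro-to-trifluoromethyl change. The working expectation for this assay is therefore a step of a 1.2-fold lower number from compound 2 to compound 3 (0.08 log units; within the scatter), that is, no movement beyond the scatter in either direction. Compound 3 is estimated at 5500 nM in this assay, with a plausible range from 2200 nM to 14000 nM.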

Compound 3, half-maximal inhibitory concentration: 5060 nM
Beside the measured number, compound 3's estimate is 1.1-fold (0.04 log units) above it; low and high end bracket the measured number.
By their numbers in this assay, from the lowest: compounds 1, 3 and 2 (each within the scatter of the next).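

In this assay, among these compounds, the first measured change at this position, 2-fluorophenyl to 2-(trifluoromethyl)phenyl, gives a 1.3-fold lower number from compound 2 to compound 3 (0.12 log units; within the scatter), so the entry of trifluoromethyl, with 4 heavy atoms where fluoro has 1, does not move the number beyond the scatter. Among the compounds shown here, until now, the only measured change lay at the amine nitrogen; with this step, changes at two separate places have been read, and each stays within the scatter on its own. No supporting measurement bears on what lies behind this result.

Still open, going by these compounds, is whether a group of a different kind on this aromatic carbon, such as an amine, a carboxylic acid or a longer alkyl chain, would give a step beyond the scatter in this assay. Also open, on these data alone, is whether the step from fluoro to trifluoromethyl reads the same when methyl, rather than (4-cyanophenyl)sulfonyl, sits on the amine nitrogen in the ring.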